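A few compounds are considered here, and "the series" means these few. Any claim that something is new, unique, unknown or untested is made for them only; others in the source may bear on it.

Compound 1, `COc1cc(C)cc(-c2nn(CC#N)cc2-c2ccc(-c3cccc(C(C)=O)c3)nc2)c1`, gives only a limit, > 100000 nM.
Compound 2, `Cc1cc(O)cc(-c2nn(CC#N)cc2-c2ccnc(-c3ccc(Oc4ccccc4)cc3)c2)c1`, gives 57700 nM.
Compound 3, `COc1cc(C)cc(-c2nn(CC#N)cc2-c2ccnc(-c3ccc(N(C)C)cc3)c2)c1`, gives only a limit, > 100000 nM.

These three compounds share a core and were tested in a functional assay on MDA-MB-231 cells (Homo sapiens) for inhibition, read by sulforhodamine B assay, with a stated time of 48 h; a lower number here means that less compound is tolerated, a higher number that more compound is tolerated. Compound 3 stands at the top of the measured range: its result is a limit, not a number, and it is the limit of > 100000 nM in this assay, at which 2 of the 3 values shown sit. Only compound 2 gives an actual number in this assay, and that number sits close to the same region. Among the measured compounds shown here, nothing more can be read from these three about how any single part of the structure matters, since no pair of them differs in one place only.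

Compound 4, `Cc1cc(O)cc(-c2nn(CC#N)cc2-c2ccnc(-c3ccc(N(C)C)cc3)c2)c1`, is the next compound, and it differs from compound 3 in one place: hydrogen in place of methyl on an oxygen on an aromatic ring. For the measured compounds named here, no measured step of this kind exists among the compounds above, so any expectation rests on the overall picture, in which all values sit high. The step from compound 3 to compound 4 is expected to be small, of about an at least 1.2-fold lower number from compound 3 to compound 4 (0.09 log units; that floor lies within the scatter), with no clear direction beyond the scatter. On that basis compound 4 is estimated at 80000 nM, within a range from 30000 nM to 200000 nM, with a real chance that this assay again reports only a limit.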

Compound 4, concentration lethal to 50% of the cells: > 100000 nM
Compound 4 ended at the assay's limit; the forecaster's own chance of this, stated with the estimate: 55%; at least 1.2-fold (0.09 log units) between middle value and limit.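

Replacing methoxy with hydroxy on the 3-methoxy-5-methylphenyl group does not yield a measured number in this assay: compound 3 and compound 4 both end at a limit, so this step cannot be read, in size or in direction. Hydroxy alone is therefore not enough to give a number, as the hydroxy-bearing compound 4 shows, while the change from phenoxy to dimethylamino on an aromatic carbon, with hydroxy kept, gives an at least 1.7-fold higher number from compound 2 to compound 4 (0.23 log units; that floor lies within the scatter). Most of the compounds now share one result: the limit of > 100000 nM in this assay, at which 3 of the 4 values shown sit.

On these data alone, whether methoxy and hydroxy differ at all stays open, as does how an ethoxy group would read at that oxygen-bearing place. Also open, as far as these compounds go, is how a carboxylic acid or a longer chain in place of dimethylamino would read in this assay.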